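Swapping the benzyl ring: from dimethoxy to chloro-trifluoromethyl

The source may report more compounds than this note shows. Statements on the series, on what has been measured and on what is new or still open speak of the compounds shown alone.

Of the compounds shown here, two sharing one core have been measured so far. Compound 1 `CC(C)(C)c1ccc(CNCCCNS(=O)(=O)c2cc(C(F)(F)F)cc(C(F)(F)F)c2)cc1` gives 2700 nM in a functional assay on ASPC1 cells (Homo sapiens) for inhibition, read by MTT assay, with a stated time of 72 h; a higher number here means a weaker inhibitor of growth, a lower number a stronger inhibitor of growth. Compound 2 `COc1ccc(CNCCCNS(=O)(=O)c2cc(C(F)(F)F)cc(C(F)(F)F)c2)cc1OC` gives 6400 nM in this assay. Among the measured compounds shown here, compound 2 therefore stands at the higher of the two numbers, and the only measured step, a 2.4-fold higher number from compound 1 to compound 2 (0.37 log units; beyond the scatter), runs toward weaker growth inhibition.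

Compound 3 `O=S(=O)(NCCCNCc1ccc(Cl)c(C(F)(F)F)c1)c1cc(C(F)(F)F)cc(C(F)(F)F)c1` is not yet measured. It differs from compound 2 in one place: 4-chloro-3-(trifluoromethyl)phenyl in place of 3,4-dimethoxyphenyl on a saturated chain carbon bound to an amine nitrogen. For the measured compounds named here, no measured step covers this exact exchange, but the one known step bears on it, since it shows what happened when the 3,4-dimethoxyphenyl was introduced in place of another substituted phenyl. Compound 3 removes the 3,4-dimethoxyphenyl again, so a modest move back toward the number of compound 1 is expected, a 2.0-fold lower number from compound 2 to compound 3 (0.30 log units; within the scatter). Compound 3 is thus estimated at 3200 nM, with a range from 1300 nM to 8000 nM.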

Compound 3, concentration for 50% growth inhibition: 9600 nM
Compound 3: middle estimate off by 3.0-fold (0.48 log units), on the low side, and the stated range ends below it.
By their numbers in this assay, from the lowest: compound 1; then compounds 2 and 3 (each within the scatter of the next).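

In this assay, exchanging a 3,4-dimethoxyphenyl, which has hydrogen-bond acceptors, for a 4-chloro-3-(trifluoromethyl)phenyl, which has none, gives a 1.5-fold higher number from compound 2 to compound 3 (0.18 log units; within the scatter), so these two quite different groups cannot be told apart at this place. The 4-(tert-butyl)phenyl now stands apart from both, since the exchange for 4-chloro-3-(trifluoromethyl)phenyl gives a 3.6-fold higher number from compound 1 to compound 3 (0.55 log units; beyond the scatter), and compound 1 is the strongest growth inhibitor of the three. No measurement shown here accounts for this difference.

The compounds shown leave open whether a different group at this place, such as an unsubstituted phenyl or a cyclohexyl, would do better or worse than the 4-(tert-butyl)phenyl. They also leave open how a longer chain between the two nitrogens of the shared core would affect growth inhibition.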